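A methyl in place of hydrogen on the aryl ether

The source may hold more compounds than are shown below. What is called first, only, known or untested is meant among the compounds shown, and "the series" means these compounds.

compound 1 `Cc1cccc(C#CCOc2ccccc2)n1` — > 10000 nM
compound 2 `Cc1cccc(C#CCOc2cccc(Cl)c2)n1` — 101 nM

Of the compounds shown here, two of this shared core have been measured in a functional assay with metabotropic glutamate receptor 5 (Homo sapiens) as the target, read by FLIPR; a lower number here means a stronger inhibitor, a higher number a weaker inhibitor. Compound 1 `Cc1cccc(C#CCOc2ccccc2)n1` gives only a limit, > 10000 nM. That figure is the limit of > 10000 nM in this assay, at which 1 of the 2 values shown sits, of the assay and not a number. Compound 2 `Cc1cccc(C#CCOc2cccc(Cl)c2)n1` gives 101 nM. Among the measured compounds shown here, the single measured step is an at least 99-fold lower number from compound 1 to compound 2 (1.99 log units; beyond the scatter).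

Compound 3 `Cc1ccc(OCC#Cc2cccc(C)n2)cc1` differs from compound 1 by methyl in place of hydrogen on an aromatic carbon. For the measured compounds named here, only the one measured step bears on it, and it concerns a chloro group at a different place on the same ring, so it speaks to compound 3 only as a sign that a substituent on this ring can move the number a long way downward. Because compound 1 sits at the limit (the limit of > 10000 nM in this assay, at which 1 of the 2 values shown sits), its true standing is not known, and the size of any step from it cannot be fixed. A step in this assay in the direction of a lower number is expected for compound 3, but smaller than the measured one, with its expected size given by an at least 3.3-fold lower number from compound 1 to compound 3 (0.52 log units; beyond the scatter). The estimate for compound 3 in this assay is 3000 nM, between 500 nM and 15000 nM.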

Compound 3, half-maximal inhibitory concentration: 115 nM
Beside the measured number, compound 3's estimate is 26-fold (1.42 log units) above it; measured number outside the range, below it.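

In this assay, a single methyl on the six-membered aromatic ring, para to a large group, is enough to produce an at least 86-fold lower number from compound 1 to compound 3 (1.93 log units; beyond the scatter). The earlier compounds had shown a large step only for chloro, at a different place on the same ring, so this result adds a second place and a second group, one of a single carbon with no hydrogen-bond donors or acceptors and no net charge. The true size of the step cannot be fixed, because compound 1 stands at a limit of the assay rather than at a number: the limit of > 10000 nM in this assay, at which 1 of the 3 values shown sits.

Compound 2 and compound 3 differ both in the group and in its place, so the compounds shown cannot separate what the group contributes from what its place contributes, and the effect of a methyl at the place held by chloro in compound 2, or of a chloro para to a large group, remains open. Also open, on these data alone, is what a methoxy, an amine or a carboxylic acid would do para to a large group on this ring.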